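The source may hold more compounds than are shown below. What is called first, only, known or untested is meant among the compounds shown, and "the series" means these compounds.

Measured so far in a physicochemical assay for solubility, in phosphate buffer; on this read-out lower numbers stand for lower solubility and higher numbers for higher solubility:
compound 1 `C[C@H](CO)N1C[C@H](C)[C@@H](CN(C)Cc2ccc(Oc3ccccc3)cc2)Oc2c(NC(=O)c3ccncc3)cccc2C1=O` gives 2000 nM
compound 2 `C[C@H]1CN([C@@H](C)CO)C(=O)c2cccc(NC(=O)c3ccncc3)c2O[C@@H]1CN(C)Cc1ccc(Cl)c(Cl)c1` gives 64000 nM

Compound 1 holds the lower of the two numbers; compound 2 sits higher by a margin beyond the scatter. The pair share nothing beyond the core, so the gap cannot be tied to one change.

Compound 3 `C[C@@H]1CN([C@@H](C)CO)C(=O)c2cccc(NC(=O)c3ccncc3)c2O[C@@H]1CN(C)Cc1ccc(Oc2ccccc2)cc1` is not yet measured. Relative to compound 1: the two compounds have the same atoms and bonds and differ only in configuration as drawn: 2 of 3 stereo elements differ; a stereocentre at a saturated ring carbon is drawn S in compound 1 and R in compound 3; a stereocentre at a saturated chain carbon is drawn R in compound 1 and S in compound 3. With the same atoms and bonds, only a modest step in this assay is expected from compound 1 to compound 3, in either direction or none beyond the scatter; the expected step is a 1.5-fold higher number from compound 1 to compound 3 (0.18 log units; within the scatter). For compound 3 the estimate is 3000 nM, with a range from 800 nM to 12000 nM.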

Compound 3, solubility: 87000 nM
For compound 3 the middle estimate is 29-fold (1.46 log units) below the measured one; measured number outside the range, above it.
By their numbers in this assay, from the lowest: compound 1; then compounds 2 and 3 (each within the scatter of the next).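

Within this assay the series now has its first readable step, a large one (a 44-fold higher number from compound 1 to compound 3 (1.64 log units; beyond the scatter)) with no atom or bond changed. Configuration at the saturated ring carbon and the saturated chain carbon, taken together, therefore matters on this read-out, and the step can be tied to configuration alone: the fact that compounds 1 and 3 differ only in the configuration as drawn.

On these data alone, the two stereocentres changed together, so their separate shares remain unknown. Also open, as far as these compounds go, is whether a carboxylic acid or a longer chain on the shared core would show the same dependence on configuration.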